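Methyl for Bromo on the Sulfonyl Aryl Group

This account rests on a few compounds, and the source may have more. Where it says the series, first, only, none or still open, it means among the compounds named here.

Of the compounds shown here, three have been measured in a functional assay on DU-145 cells (Homo sapiens) for inhibition, read by trypan blue exclusion, with a stated time of 96 h; on this read-out lower numbers stand for stronger inhibition of growth and higher numbers for weaker inhibition of growth. Compound 1 `Cc1ccc(S(=O)(=O)/C(=C/c2ccccc2F)C(=O)c2ccc(Cl)cc2)cc1` gives 2500 nM, compound 2 `CC(=O)Oc1ccc(/C=C(\C(=O)c2ccc(Cl)cc2)S(=O)(=O)c2ccc(C)cc2)cc1` gives 25000 nM, and compound 3 `COc1ccc(/C=C(\C(=O)c2ccc(Cl)cc2)S(=O)(=O)c2ccc(Br)cc2)cc1O` gives 10000 nM. Compound 3 thus holds the second highest of the three numbers, lying between compound 2 and compound 1. Among the compounds with values here, the only step between compounds differing in one place, a 10-fold higher number from compound 1 to compound 2 (1.00 log units; beyond the scatter), concerns the aryl group on the chain, not the (4-bromophenyl)sulfonyl group. Compound 4 `COc1ccc(/C=C(\C(=O)c2ccc(Cl)cc2)S(=O)(=O)c2ccc(C)cc2)cc1O` differs from compound 3 by methyl in place of bromo on an aromatic carbon. Within the data shown here, no measured step bears on this change, so the data give no ground to expect a step beyond the scatter. Compound 4 is therefore expected to give 10000 nM, within 4000 nM to 25000 nM, an estimated step of no change at the digits printed from compound 3 to compound 4 (within the scatter).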

Compound 4, concentration for 50% growth inhibition: 1000 nM
Estimate against measurement, compound 4: 10-fold (1.00 log units) above, and the stated range ends above it.
By their numbers in this assay, from the lowest: compound 4; then compound 1; then compound 3; then compound 2.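

In this assay, within the data shown here, methyl in place of bromo on the sulfonyl aryl group, the first change at this position that can be read, gives a 10-fold lower number from compound 3 to compound 4 (1.00 log units; beyond the scatter). With the 4-methylphenyl group in place, 3-hydroxy-4-methoxyphenyl on the chain gives a 25-fold lower number from compound 2 to compound 4 (1.40 log units; beyond the scatter) against 4-acetoxyphenyl and a 2.5-fold lower number from compound 1 to compound 4 (0.40 log units; beyond the scatter) against 2-fluorophenyl. Nothing available here explains these steps.

As far as these compounds go, it remains open where an amine or a carboxylic acid at this ring position would fall relative to methyl and bromo. From the compounds shown here alone, whether methyl in place of bromo gives a similar step with other aryl groups on the chain also remains open.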